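Ethoxy for cyclopropyl on the carbonyl: compound 4

This account rests on a few compounds, and the source may have more. Where it says the series, first, only, none or still open, it means among the compounds named here.

Values in a functional assay on PC-3 cells (Homo sapiens) for inhibition, read by MTT assay, with a stated time of 48 h; a higher number here means a weaker inhibitor, a lower number a stronger inhibitor:
- compound 1 `COc1cc(-c2nnc(SC)n2-c2ccc(N(C)C)cc2)cc(OC)c1OC`: > 60000 nM, a limit of the assay
- compound 2 `COc1ccc(C(=O)CSc2nnc(-c3cc(OC)c(OC)c(OC)c3)n2-c2ccc(N(C)C)cc2)cc1`: 22000 nM
- compound 3 `COc1cc(-c2nnc(SCC(=O)C3CC3)n2-c2ccc(N(C)C)cc2)cc(OC)c1OC`: 45900 nM

Compound 3 has the higher of the two actual numbers, at 45900 nM. Compound 4 `CCOC(=O)CSc1nnc(-c2cc(OC)c(OC)c(OC)c2)n1-c1ccc(N(C)C)cc1` carries ethoxy in place of cyclopropyl on a carbonyl carbon. The nearest measured change at this carbonyl carbon, a 2.1-fold higher number from compound 2 to compound 3 (0.32 log units; beyond the scatter), is modest. Adding the carbonyl-bearing group gave an at least 2.7-fold lower number from compound 1 to compound 2 (0.43 log units; beyond the scatter) and an at least 1.3-fold lower number from compound 1 to compound 3 (0.11 log units; that floor lies within the scatter). Going by the values given here, no measured step installs ethoxy, so no change beyond the scatter is expected in this assay. Compound 4 is estimated at 45000 nM, within 20000 nM to 85000 nM, an expected 1.0-fold lower number from compound 3 to compound 4 (0.01 log units; within the scatter).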

Compound 4, half-maximal inhibitory concentration: > 60000 nM
Compound 4: only a limit was reported; the forecaster's own chance of this, stated with the estimate: 30%; middle value at least 1.3-fold (0.12 log units) away from the limit.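

In this assay compound 4 gives > 60000 nM, which is a limit of the assay and not a number. With ethoxy in place of 4-methoxyphenyl on a carbonyl carbon, the series shows an at least 2.7-fold higher number from compound 2 to compound 4 (0.43 log units; beyond the scatter), so this position does respond to that change, whereas an at least 1.3-fold higher number from compound 3 to compound 4 (0.11 log units; that floor lies within the scatter) does not separate ethoxy from cyclopropyl. The step between the two limits cannot be read: the limit of > 60000 nM in this assay, at which 2 of the 4 values shown sit.

From the compounds shown here alone, whether a carboxylic acid or an amine in place of ethoxy on a carbonyl carbon would lower the number stays open. So does the effect of 4-chlorophenyl in place of 4-methoxyphenyl there.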